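A Shorter Chain for Compound 4

The source may report more compounds than this note shows. Statements on the series, on what has been measured and on what is new or still open speak of the compounds shown alone.

The series was examined in an ADME assay on HEK293 cells (Homo sapiens) for inhibition, read by MTT assay, with a stated time of 96 h; a lower number here means a stronger inhibitor of growth, a higher number a weaker inhibitor of growth. Compound 1, `O=C(NCCCCCCSSCCCCCCNC(=O)c1cc(-c2ccncc2)n[nH]1)c1cc(-c2ccncc2)n[nH]1`, carries two copies of the shared core joined through a long chain, and in this assay compound 1 gives 14800 nM. Compound 2, `CCCC(=O)SCCCCCCNC(=O)c1cc(-c2ccncc2)n[nH]1`, carries a single copy of that core. For compound 2 this assay records only a limit, > 50000 nM, and not a number. Compound 3, `CCCCCCCC/C=C\CCCCCCCC(=O)SCCCCCCNC(=O)c1cc(-c2ccncc2)n[nH]1`, bears a long chain in place of the short one. For compound 3 too this assay records only a limit, > 50000 nM. Compound 2 therefore stands at the edge of what this assay reports, together with compound 3, while compound 1 alone gives a measured number; the limit of > 50000 nM in this assay, at which 2 of the 3 values shown sit, marks where compound 2 sits.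

Compound 4, `CCC(=O)SCCCCCCNC(=O)c1cc(-c2ccncc2)n[nH]1`, has not yet been measured. It differs from compound 2 by hydrogen in place of methyl on a saturated chain carbon, two bonds along the chain from a carbonyl carbon. Going by the values given here, no step between measured compounds of this set involves this kind of change, so the expectation rests on where compound 2 stands. Such a small change is expected to give no step beyond the scatter, a step that the limit leaves unreadable from compound 2 to compound 4. Compound 4 is estimated at 60000 nM in this assay, within a range from 30000 nM to 150000 nM, and it is expected most likely to return only a limit as well.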

Compound 4, concentration for 50% growth inhibition: > 50000 nM
Compound 4: a limit, no number; the forecaster's own chance of this, stated with the estimate: 80%; the middle value does not contradict the limit.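

In this assay compound 4 returns only a limit, > 50000 nM, and not a number. Compound 2 also stands at a limit, so no step can be read between compound 2 and compound 4: the limit of > 50000 nM in this assay, at which 3 of the 4 values shown sit.

The compounds shown leave open whether hydrogen in place of methyl at this place changes growth inhibition at all.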